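One Methyl Change, Measured Once, Expected Once More

This account rests on a few compounds, and the source may have more. Where it says the series, first, only, none or still open, it means among the compounds named here.

Compound 1, `N/C(=N\NC(=S)N1CCCCCC1)c1ccccn1`: 72.3%
Compound 2, `Cc1ccnc(/C(N)=N/NC(=S)N2CCSCC2)c1`: 75.3%
Compound 3, `N/C(=N\NC(=S)N1CCSCC1)c1ccccn1`: 81.3%

Of the compounds shown here, three have so far been tested in a functional assay on A-431 cells (Homo sapiens) for cytotoxicity, read by MTT assay, with a stated time of 72 h, tested at 30 uM; on this read-out higher numbers stand for more inhibition of growth at the one concentration tested and lower numbers for less inhibition of growth. In this assay compound 3 gives 81.3%, compound 2 gives 75.3% and compound 1 gives 72.3%. Compound 1 has the lowest of the three numbers, but its gaps to compound 2 and to compound 3 are both within the usual scatter, so no order among the three can be read from these values.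

Compound 1 and compound 3 carry different cores; the difference between the two cores is not broken down here. Compound 3 and compound 2, by contrast, differ in a single place: methyl in place of hydrogen on an aromatic carbon. This step gave a number 6 percentage points lower from compound 3 to compound 2 (within the scatter).

Compound 4, `Cc1ccnc(/C(N)=N/NC(=S)N2CCCCCC2)c1`, has not yet been measured. It differs from compound 1 by the same change, described in the same words and at the same place: methyl in place of hydrogen on an aromatic carbon. Going by the values given here, since the one measured instance of this change, a number 6 percentage points lower from compound 3 to compound 2 (within the scatter), stayed within the scatter, compound 4 is expected to show a step of a number 4.3 percentage points lower from compound 1 to compound 4 (within the scatter), an expectation that rests on that single pair. Compound 4 is therefore estimated to give 68% in this assay, with a likely range from 55% to 80%.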

Compound 4, percent growth inhibition at one concentration: 63.4%
Beside the measured number, compound 4's estimate is 4.6 percentage points above it, and the stated range covers the measured number.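

In this assay, methyl in place of hydrogen on an aromatic carbon now has a second reading, which gives a number 8.9 percentage points lower from compound 1 to compound 4 (within the scatter). Set beside the first reading, on the other core, the two steps do not differ: the same change on two cores in this assay, a number 6 percentage points lower (within the scatter) from compound 3 to compound 2 and a number 8.9 percentage points lower (within the scatter) from compound 1 to compound 4, 2.9 percentage points apart, within the scatter of two such steps. In these two pairs the change therefore carries from the core of compound 3 to the core of compound 1 with no difference that can be told apart, but each step lies within the scatter on its own, so this shows neither a real effect of the methyl at the one concentration tested nor how the change would behave on any further core.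

The compounds shown carry only hydrogen or methyl on the aromatic carbon opposite the ring nitrogen, which leaves open what an ethyl group, a methoxy group or a chlorine atom would give at that place. Equally open, as far as these compounds go, is what a carboxylic acid or a longer chain on the same ring would give, and how any of the four compounds would read at a concentration other than the single one used here.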